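One Ring Swap at the Edge of a Limit

A few compounds are considered here, and "the series" means these few. Any claim that something is new, unique, unknown or untested is made for them only; others in the source may bear on it.

- compound 1 (`OC[C@H]1O[C@@H](n2cnc3c(NCc4ccc(Cl)c(Cl)c4)ncnc32)[C@H](O)[C@@H]1O`) gives 88800 nM as a measured number
- compound 2 (`OC[C@H]1O[C@@H](n2cnc3c(NCc4ccc(F)cc4Cl)ncnc32)[C@H](O)[C@@H]1O`) gives > 166000 nM as a limit
- compound 3 (`OC[C@H]1O[C@@H](n2cnc3c(NCc4cc(O)cc(O)c4)ncnc32)[C@H](O)[C@@H]1O`) gives > 166000 nM as a limit

All three were tested in a functional assay on MCF cells (Homo sapiens) for antiproliferative activity, with a stated time of 72 h (on this read-out higher numbers stand for weaker inhibition and lower numbers for stronger inhibition), and share one core. Only compound 1 carries a true number there. Compound 3 stands at the limit of > 166000 nM in this assay, at which 2 of the 3 values shown sit, and so is known only through a limit.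

Compound 4 (`Cc1ccc(O)c(CNc2ncnc3c2ncn3[C@@H]2O[C@H](CO)[C@@H](O)[C@H]2O)c1`) has not yet been measured. The change from compound 3 (2-hydroxy-5-methylphenyl in place of 3,5-dihydroxyphenyl on a saturated chain carbon bound to a nitrogen on an aromatic ring) puts 2-hydroxy-5-methylphenyl in place of 3,5-dihydroxyphenyl on a saturated chain carbon bound to a nitrogen on an aromatic ring.

Among the compounds with values here, no measured step tests this swap directly. The nearest evidence is an at least 1.8-fold higher number from compound 1 to compound 2 (0.27 log units; that floor lies within the scatter) and an at least 1.8-fold higher number from compound 1 to compound 3 (0.27 log units; that floor lies within the scatter) as the ring on that chain carbon changes. Between the two limits there is only a step that the two limits leave unreadable from compound 2 to compound 3 to go on. Within the data shown here, compound 1 at 88800 nM is the sole true number. Compound 4 is expected to stay in the same weak region of this assay with no step beyond the scatter, and it may report only a limit. The expected move is an at least 1.1-fold lower number from compound 3 to compound 4 (0.07 log units; that floor lies within the scatter) by this estimate. For compound 4 the estimated value is 140000 nM with an expected range of 55000 nM to 300000 nM overall.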

Compound 4, half-maximal inhibitory concentration: > 166000 nM
Compound 4 gave a limit, no number (the forecaster's own chance of this, stated with the estimate: 60%); middle value at least 1.1-fold (0.07 log units) from the limit.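

Compound 4 joins compounds 2 and 3 at the same limit in this assay, so it too gives no true number: the limit of > 166000 nM in this assay, at which 3 of the 4 values shown sit. Set against compound 1, the one compound with a true number, the result reads as an at least 1.8-fold higher number from compound 1 to compound 4 (0.27 log units; that floor lies within the scatter). The steps from compound 2 and from compound 3 to compound 4 cannot be read, yet the new result still adds something: 2-hydroxy-5-methylphenyl, with one hydroxy group and a methyl group on the ring, now stands with 2-chloro-4-fluorophenyl and 3,5-dihydroxyphenyl as a third ring that yields only a limit, and compound 1, with 3,4-dichlorophenyl, remains the single exception among the four.

A limit gives no size, and the floor of each readable step lies within the scatter, which leaves open whether these rings truly differ from one another or from 3,4-dichlorophenyl. Also open, going by these compounds, is how this position would respond to a ring bearing an amine or a carboxylic acid, or to a longer chain joining the ring to the nitrogen.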